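The compounds below may be only part of what the source reports. "The series", "measured", "known", "first", "only" and "open" are said of these compounds alone.

Measured compounds:
Compound 1, `O=C(O)c1ccc(CN2CCC[C@H](OCc3cc(Cl)cc(Cl)c3)[C@@H]2c2ccccc2)s1`, gives 76000 nM in an assay on isolated protein for activation of cGMP-dependent protein kinase 1 (Homo sapiens), read by ADP-Glo, with stated times of 120 min and 40 min; on this read-out lower numbers stand for an effect already at smaller amounts and higher numbers for an effect only at larger amounts of compound.
Compound 2, `Clc1cc(Cl)cc(CO[C@H]2CCCN(Cc3ccccn3)[C@H]2c2ccccc2)c1`, is reported in this assay only as the limit > 200000 nM.

Compound 2 thus stands with no number of its own but at the limit of > 200000 nM in this assay, at which 1 of the 2 values shown sits, showing no measurable effect in the range tested. Compound 3, `Clc1cc(Cl)cc(CO[C@H]2CCCN(Cc3ncco3)[C@H]2c2ccccc2)c1`, differs from compound 2 in one place: 1,3-oxazol-2-yl in place of pyridin-2-yl on a saturated chain carbon bound to an amine nitrogen in a ring. Among the compounds with values here, the only measured step at this position is an at least 2.6-fold higher number from compound 1 to compound 2 (0.42 log units; beyond the scatter), which carried the number from a weak value to the limit, but it does not exchange one small aromatic ring for another, so it bears on the new step only loosely. With compound 2 already at the limit, no shift beyond the scatter in this assay is expected in either direction, and a second limit is the likelier outcome. Compound 3 is therefore estimated at about 250000 nM, with a range from 100000 nM to 600000 nM, which would amount to a step that the limit leaves unreadable from compound 2 to compound 3.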

Compound 3, half-maximal effective concentration: > 200000 nM
Compound 3 gave a limit, no number; the forecaster's own chance of this, stated with the estimate: 70%; the middle value does not contradict the limit.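

In this assay compound 3 also gives only a limit, > 200000 nM. Exchanging 5-carboxythiophen-2-yl for 1,3-oxazol-2-yl on the saturated chain carbon bound to an amine nitrogen in a ring gives an at least 2.6-fold higher number from compound 1 to compound 3 (0.42 log units; beyond the scatter), so a second group at this position joins pyridin-2-yl in leaving the compound without a number, and among these three compounds only compound 1 has one: the limit of > 200000 nM in this assay, at which 2 of the 3 values shown sit. The step between compound 2 and compound 3 cannot be read, so pyridin-2-yl and 1,3-oxazol-2-yl cannot be ranked.

The compounds shown leave open whether the number of compound 1 depends on the carboxylic acid, on the thiophene ring, or on both. They also leave open whether a carboxylic acid on a 1,3-oxazol-2-yl or pyridin-2-yl ring, or on a longer chain, would bring a number back.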